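Replacing (3,4-dimethylphenyl)amino with piperidin-1-yl

The compounds below may be only part of what the source reports. "The series", "measured", "known", "first", "only" and "open" are said of these compounds alone.

Results in a functional assay on MGC-803 cells (Homo sapiens) for inhibition, read by sulforhodamine B assay (on this read-out higher numbers stand for weaker inhibition and lower numbers for stronger inhibition), so far:
compound 1 (`O=C1C(NC2CCCC2)=CC(=O)c2c1nc1n2[C@H]2OC[C@@H](O)[C@H]2OC1`): > 16000 nM (a limit)
compound 2 (`Cc1ccc(NC2=CC(=O)c3c(nc4n3[C@H]3OC[C@@H](O)[C@H]3OC4)C2=O)cc1C`): 1050 nM (a number)

Going by the values given here, compound 2, at 1050 nM in this assay, holds the only actual number so far. Compound 1 gives only a limit, > 16000 nM, and no number.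

Compound 3 (`O=C1C(N2CCCCC2)=CC(=O)c2c1nc1n2[C@H]2OC[C@@H](O)[C@H]2OC1`) differs from compound 2 by piperidin-1-yl in place of (3,4-dimethylphenyl)amino on a double-bonded ring carbon. Among the compounds with values here, one measured step bears on this, an at least 15-fold lower number from compound 1 to compound 2 (1.18 log units; beyond the scatter), which put 3,4-dimethylphenyl in place of cyclopentyl on an amine nitrogen. Compound 3 gives up that aromatic ring, so a large move towards weaker inhibition is expected, largely reversing the step to compound 2. The estimated change is a 9.5-fold higher number from compound 2 to compound 3 (0.98 log units; beyond the scatter) in this assay and may end at the limit. For compound 3 the expected value is 10000 nM (estimated range 3000 nM to 30000 nM).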

Compound 3, half-maximal inhibitory concentration: > 4000 nM
Compound 3 was reported as a limit (the forecaster's own chance of this, stated with the estimate: 45%); the middle value lies beyond the limit too.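

In this assay, compound 3 gives only a limit, > 4000 nM. The change at this double-bonded ring carbon still produces an at least 3.8-fold higher number from compound 2 to compound 3 (0.58 log units; beyond the scatter), so a second non-aromatic ring group, this time attached through its ring nitrogen and carrying no hydrogen on that nitrogen, also falls on the weaker side of compound 2. Going by these compounds, compound 1 and compound 3 both end in limits, so the step between them cannot be read, and whether cyclopentylamino and piperidin-1-yl differ at this position remains unknown.

The compounds shown leave open whether the two methyl groups of compound 2 contribute, which a plain phenylamino group would test. They also leave open whether the aromatic ring must sit directly on the amine nitrogen, which a benzylamino group would test.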